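One Fluoro Group Fewer: From Compound 3 to Compound 4

The source may report more compounds than this note shows. Statements on the series, on what has been measured and on what is new or still open speak of the compounds shown alone.

Three small fluorinated acids were tested in a toxicity assay on the whole organism (strain CD-1) for cytotoxicity, with Mus musculus as the target, with a stated time of 14 days, at a dose of 300 mg/kg by the intraperitoneal route; on this read-out lower numbers stand for a stronger effect and higher numbers for a weaker effect at the one dose given. Compound 1 `COc1c(C(=O)O)cc(F)c(F)c1F` gives 0%. Compound 2 `O=C(O)c1c(O)c(F)c(F)c(F)c1F` gives 0%, and compound 3 `O=C(O)c1cc(F)c(F)c(F)c1O` gives 0%. Compound 3 therefore stands level with both other compounds at the digits shown, and the two steps leading to it are equally quiet: no change at the digits printed from compound 1 to compound 3 (within the scatter), and no change at the digits printed from compound 2 to compound 3 (within the scatter).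

Compound 4 `O=C(O)c1ccc(F)c(F)c1O` has not yet been measured. It differs from compound 3 by hydrogen in place of fluoro on an aromatic carbon. The step from compound 2 to compound 3 bears directly on this change, since it is also a hydrogen in place of fluoro on an aromatic carbon, and it showed no change within the scatter; the step from compound 1 to compound 3 showed none either. No step beyond the scatter is therefore expected, and the step is expected to be no change at the digits printed from compound 3 to compound 4 (within the scatter). Compound 4 is expected to give about 0%, between 0% and 10%.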

Compound 4, a percentage reported as activity, at one dose (the size of the read-out at that dose, not a potency): 33%
For compound 4 the middle estimate is 33 percentage points below the measured one; the whole stated range lies below it.
By their numbers in this assay, from the lowest: compounds 1, 2 and 3 (each within the scatter of the next); then compound 4.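

In this assay, going by these compounds alone, the fluoro group on this carbon, para to a hydroxy group and meta to a carboxy group, matters in a way the earlier compounds gave no sign of, with a number 33 percentage points higher from compound 3 to compound 4 (beyond the scatter). Hydrogen in place of fluoro is therefore not a silent change everywhere on the ring: it made no difference beyond the scatter on the carbon changed between compound 2 and compound 3, but here it weakens the effect at the one dose given. No measurement shown explains this difference.

The compounds shown leave open whether another group on this carbon, such as a chlorine atom, a methoxy group or an amine, would keep the read-out at the level of compound 3. They also leave open what removing either remaining fluoro group from compound 4 would do.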